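The source may hold more compounds than are shown below. What is called first, only, known or untested is meant among the compounds shown, and "the series" means these compounds.

Compound 1 `CC(C)c1ccc(-c2nc(SCc3cn(CC(=O)NC(=O)Nc4ccccn4)nn3)nc(Nc3ccccc3F)c2C#N)cc1` gives 8380 nM; compound 2 `COc1ccc(Nc2nc(SCc3cn(CC(=O)NC(=O)Nc4ccccn4)nn3)nc(-c3ccc(C(C)C)cc3)c2C#N)cc1` gives 360 nM; compound 3 `Cc1ccccc1Nc1nc(SCc2cn(CC(=O)NC(=O)Nc3ccccn3)nn2)nc(-c2ccc(C(C)C)cc2)c1C#N` gives 18600 nM.

In a functional assay on B16-F10 cells (Mus musculus) for inhibition, read by MTT assay, with a stated time of 72 h (a higher number here means a weaker inhibitor, a lower number a stronger inhibitor), compound 3 stands with the highest number of the three, the nearest being a 2.2-fold higher number from compound 1 to compound 3 (0.35 log units; beyond the scatter) and the furthest a 52-fold higher number from compound 2 to compound 3 (1.71 log units; beyond the scatter). Compound 4 `COc1ccccc1Nc1nc(SCc2cn(CC(=O)NC(=O)Nc3ccccn3)nn2)nc(-c2ccc(C(C)C)cc2)c1C#N` differs from compound 3 by methoxy in place of methyl on an aromatic carbon. Within the data shown here, two measured steps bear on this change: the large one, a 52-fold higher number from compound 2 to compound 3 (1.71 log units; beyond the scatter), shows a methoxy group on that ring carrying a strongly lower number, though at a different place, while the modest one, a 2.2-fold higher number from compound 1 to compound 3 (0.35 log units; beyond the scatter), shows that small groups at this place move the number little. A moderate lowering is therefore expected, a 3.1-fold lower number from compound 3 to compound 4 (0.49 log units; beyond the scatter). Compound 4 is estimated at 6000 nM, with a range from 1500 nM to 25000 nM.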

Compound 4, half-maximal inhibitory concentration: 34600 nM
The estimate for compound 4 lay 5.8-fold (0.76 log units) below the measured number; the measured number lies above the stated range.
By their numbers in this assay, from the lowest: compound 2; then compound 1; then compounds 3 and 4 (each within the scatter of the next).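

In this assay, methoxy in place of methyl at this place gives a 1.9-fold higher number from compound 3 to compound 4 (0.27 log units; within the scatter), so the two groups are not told apart here. The 2-methoxyphenyl in place of 4-methoxyphenyl gives a 96-fold higher number from compound 2 to compound 4 (1.98 log units; beyond the scatter), and methoxy in place of fluoro gives only a 4.1-fold higher number from compound 1 to compound 4 (0.62 log units; beyond the scatter), so among these compounds a methoxy group carries the low number of compound 2 only in the 4-methoxyphenyl form. Nothing shown here explains these numbers.

From the compounds shown here alone, it remains open whether a 4-methylphenyl or 4-fluorophenyl group would also give a low number, or whether the effect is specific to methoxy. Going by these compounds, how an amine or a carboxylic acid would behave on this ring also remains open.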